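This account rests on a few compounds, and the source may have more. Where it says the series, first, only, none or still open, it means among the compounds named here.

The measured compounds:
compound 1, `Cc1ccc(C2=Nn3c(nnc3C(C)c3ccc(-c4ccccc4)c(F)c3)SC2)cc1`, giving 5000 nM in a functional assay on MCF7 cells (Homo sapiens) for inhibition, read by sulforhodamine B assay, with a stated time of 72 h; a higher number here means a weaker inhibitor, a lower number a stronger inhibitor;
compound 2, `CC(c1ccc(-c2ccccc2)c(F)c1)c1nnc2n1N=C(c1ccc(Cl)cc1Cl)CS2`, giving 7600 nM;
compound 3, `COc1ccc(C2=Nn3c(nnc3C(C)c3ccc(-c4ccccc4)c(F)c3)SC2)cc1`, giving 2600 nM.

Among these three, compound 3 gives the lowest number. Its distance from compound 2 is a 2.9-fold lower number from compound 2 to compound 3 (0.47 log units; beyond the scatter), a modest step, whereas its distance from compound 1 is a 1.9-fold lower number from compound 1 to compound 3 (0.28 log units; within the scatter), so compound 3 and compound 1 cannot be told apart on these numbers. Compound 4, `CC(c1ccc(-c2ccccc2)c(F)c1)c1nnc2n1N=C(c1ccc(F)cc1)CS2`, is the next step: fluoro in place of methoxy on an aromatic carbon. Among the compounds with values here, two measured steps bear on it. Exchanging methyl for methoxy on the same aromatic carbon, a 1.9-fold lower number from compound 1 to compound 3 (0.28 log units; within the scatter), stayed within the scatter; exchanging the whole aryl group, a 2.9-fold lower number from compound 2 to compound 3 (0.47 log units; beyond the scatter), gave a modest step. Within the data shown here, no measured step introduces a fluoro on this ring, so the direction rests on the small moves seen so far. A small rise in the number is expected, a 1.3-fold higher number from compound 3 to compound 4 (0.13 log units; within the scatter), and a step within the scatter is as likely as not. Compound 4 is therefore estimated at 3500 nM, with a range from 1500 nM to 8000 nM.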

Compound 4, half-maximal inhibitory concentration: 8100 nM
Compound 4: the middle estimate sits 2.3-fold (0.36 log units) below what was measured; measured number above the stated range.
By their numbers in this assay, from the lowest: compounds 3, 1, 2 and 4 (each within the scatter of the next, the first and the last beyond it).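

In this assay, replacing 4-methoxyphenyl with 4-fluorophenyl gives a step beyond the scatter (a 3.1-fold higher number from compound 3 to compound 4 (0.49 log units; beyond the scatter)), so this group on the aromatic carbon can shift the number, and a modest separation now appears between the methoxy and fluoro compounds. Compound 4 cannot be told apart from compound 2 (a 1.1-fold higher number from compound 2 to compound 4 (0.03 log units; within the scatter)) or compound 1 (a 1.6-fold higher number from compound 1 to compound 4 (0.21 log units; within the scatter)), so compound 3 separates from compounds 2 and 4 but still not from compound 1, which goes against any simple methoxy-versus-the-rest reading. Nothing in the available data explains the difference between methoxy and fluoro.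

On these data alone, it remains open whether an ethoxy group, a longer chain on the same oxygen, would carry the number further than methoxy does. The compounds shown also leave open how an amine or a carboxylic acid at this place would compare.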